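Cytotoxicity at the Assay Limit Across Three Ester Analogues

This account rests on a few compounds, and the source may have more. Where it says the series, first, only, none or still open, it means among the compounds named here.

Compound 1 `COc1ccccc1C(=O)OC1CCC(CN2CCN(c3cc(=O)c4cc(C(F)(F)F)cc([N+](=O)[O-])c4s3)CC2)CC1`, compound 2 `O=C(OC1CCC(CN2CCN(c3cc(=O)c4cc(C(F)(F)F)cc([N+](=O)[O-])c4s3)CC2)CC1)c1cccs1` and compound 3 `Cc1ccc(C(=O)OC2CCC(CN3CCN(c4cc(=O)c5cc(C(F)(F)F)cc([N+](=O)[O-])c5s4)CC3)CC2)cc1` share one core and differ only in the aromatic group attached to the ester carbonyl. In an ADME assay on Vero cells (Chlorocebus sabaeus) for cytotoxicity, read by MTT assay, with a stated time of 48 h (a lower number here means a stronger inhibitor, a higher number a weaker inhibitor), compound 1 reaches only the limit of the assay, > 64 ug/mL. Compound 2 likewise gives only a limit, > 64 ug/mL. Compound 3 too stands at a limit, > 64 ug/mL. All three values sit at the same limit (the limit of > 64 ug/mL in this assay, at which 3 of the 3 values shown sit), so the steps a step that the two limits leave unreadable from compound 1 to compound 2, a step that the two limits leave unreadable from compound 1 to compound 3 and a step that the two limits leave unreadable from compound 2 to compound 3 cannot be sized. Compound 4 `COc1cccc(C(=O)OC2CCC(CN3CCN(c4cc(=O)c5cc(C(F)(F)F)cc([N+](=O)[O-])c5s4)CC3)CC2)c1` carries the change (3-methoxyphenyl in place of 4-methylphenyl on a carbonyl carbon). With every related aromatic group having left the read-out at the limit (the limit of > 64 ug/mL in this assay, at which 3 of the 3 values shown sit), compound 4 is expected to remain there as well, a step that the limit leaves unreadable from compound 3 to compound 4 of no readable size. Compound 4 is estimated at 90 ug/mL, within 40 ug/mL to 200 ug/mL.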

Compound 4, half-maximal inhibitory concentration: > 64 ug/mL
Compound 4: only a limit was reported; the forecaster's own chance of this, stated with the estimate: 85%; the middle value is on the limit's open side.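

Compound 4 also gives only a limit, so the steps to it from compound 1, compound 2 and compound 3 cannot be read: the limit of > 64 ug/mL in this assay, at which 4 of the 4 values shown sit.

As far as these compounds go, whether the aromatic groups on the ester carbonyl differ at all in this assay remains open.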